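This account rests on a few compounds, and the source may have more. Where it says the series, first, only, none or still open, it means among the compounds named here.

Of the compounds shown here, three sharing one core have been measured. Compound 1 `CC(C)(c1ccccc1)c1nc2c(C(F)(F)F)cccc2c(C(=O)O)c1O` gives 59% in an assay on isolated protein for inhibition of P-selectin glycoprotein ligand 1 (Homo sapiens), read by surface plasmon resonance, tested at 250 uM; a lower number here means less inhibition, a higher number more inhibition at the concentration tested (going by the name of the read-out). Compound 2 `CCC(c1ccccc1)c1nc2c(C(F)(F)F)cccc2c(C(=O)O)c1O` gives 55% and compound 3 `CC(C)C(c1ccccc1)c1nc2c(C(F)(F)F)cccc2c(C(=O)O)c1O` gives 58%. Compound 2 holds the lowest number of the three, yet both others sit within the scatter of it. The step of a number 4 percentage points lower from compound 1 to compound 2 (within the scatter) and the step of a number 3 percentage points higher from compound 2 to compound 3 (within the scatter) both reshaped the same substituent without a shift beyond the scatter. Compound 4 `O=C(O)c1c(O)c(C2(c3cccs3)CC2)nc2c(C(F)(F)F)cccc12` differs from compound 2 by 1-(thiophen-2-yl)cyclopropyl in place of 1-phenylpropyl on an aromatic carbon. Both measured steps bear on this change, as they touch the same place, and both were small, so no step beyond the scatter is expected in either direction, though this change is larger than either precedent. Compound 4 is therefore estimated at 54%, within 38% to 68%. The expected step is a number 1 percentage points lower from compound 2 to compound 4 (within the scatter).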

Compound 4, a percentage reported as inhibition, at one concentration (the size of the read-out at that concentration, not a potency): 15%
Compound 4: the middle estimate sits 39 percentage points above what was measured, and the stated range ends above it.
By their numbers in this assay, from the lowest: compound 4; then compounds 2, 3 and 1 (each within the scatter of the next).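

In this assay, among these compounds, this position proves far less forgiving than the earlier compounds suggested: 1-(thiophen-2-yl)cyclopropyl in place of 1-phenylpropyl gives a number 40 percentage points lower from compound 2 to compound 4 (beyond the scatter), and in place of 1-methyl-1-phenylethyl it gives a number 44 percentage points lower from compound 1 to compound 4 (beyond the scatter). Reshaping the chain around the six-membered aromatic ring had moved nothing beyond the scatter, whereas this change, which brings a three-membered ring and a five-membered aromatic ring, does. No measured evidence accounts for the drop. The compounds shown leave open which of the two ring changes carries it; 1-phenylcyclopropyl and 1-(thiophen-2-yl)propyl would separate them.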